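Adding a nitro group to compound 3

The compounds below may be only part of what the source reports. "The series", "measured", "known", "first", "only" and "open" are said of these compounds alone.

In a functional assay on U-937 cells (Homo sapiens) for antiproliferative activity, read by MTT assay, with a stated time of 72 h (on this read-out higher numbers stand for weaker inhibition and lower numbers for stronger inhibition), compound 3 (`O=C(CCCCCCc1nc(-c2ccccc2)no1)C(F)(F)F`) gives 410 nM and lies within the scatter of both other measured compounds: compound 1 (`O=C(CCCCCCc1nc(-c2cccnc2)no1)NO`) gives 350 nM in this test and compound 2 (`Nc1ccccc1NC(=O)CCCCCCc1nc(-c2ccccc2)no1`) gives 730 nM in the same test. Compound 4 (`O=C(CCCCCCc1nc(-c2ccc([N+](=O)[O-])cc2)no1)C(F)(F)F`) is compound 3 with one change: nitro in place of hydrogen on an aromatic carbon, para to a large group (nitro in place of hydrogen on an aromatic carbon). Within the data shown here, only one single-place step has been measured (a 1.8-fold lower number from compound 2 to compound 3 (0.25 log units; within the scatter)) and it swaps (2-aminophenyl)amino for trifluoromethyl on a carbonyl carbon, which is not where the nitro goes. Compound 1 differs from compound 3 in more than one place, so it cannot isolate this change either. The data therefore give no direct guide to adding nitro, and no step beyond the scatter is expected in this assay for now. The estimated step is small (a 1.2-fold higher number from compound 3 to compound 4 (0.09 log units; within the scatter)) and leans slightly towards weaker inhibition. In this assay the estimate for compound 4 is 500 nM with a range from 180 nM to 1400 nM as the expected span.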

Compound 4, half-maximal inhibitory concentration: 3680 nM
For compound 4 the middle estimate is 7.4-fold (0.87 log units) below the measured one, outside the stated range (above it).
By their numbers in this assay, from the lowest: compounds 1, 3 and 2 (each within the scatter of the next, the first and the last beyond it); then compound 4.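

Up to this point, the only single-place step sat on a carbonyl carbon and stayed within the scatter, so nothing showed how the aromatic ring responds to change. In this assay, among these compounds, nitro in place of hydrogen on an aromatic carbon, para to a large group, gives a 9.0-fold higher number from compound 3 to compound 4 (0.95 log units; beyond the scatter) and this is the first single-place step beyond the scatter. This position is therefore sensitive to substitution, at least for this one group, but nothing shown here offers a reason for the loss.

From the compounds shown here alone, whether any group at this place weakens inhibition or nitro alone does so stays open, and an amine or a methoxy group on the same aromatic carbon would help to tell. Also open, going by these compounds, is whether nitro has the same effect when (2-aminophenyl)amino, as in compound 2, sits on the carbonyl carbon.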